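A Methylpiperazine Enters a Level Series

The source may hold more compounds than are shown below. What is called first, only, known or untested is meant among the compounds shown, and "the series" means these compounds.

In a functional assay on SF-268 cells (Homo sapiens) for cytotoxicity, read by MTT assay, with a stated time of 3 days (on this read-out lower numbers stand for stronger inhibition and higher numbers for weaker inhibition), compound 1 `N#Cc1c(O)nc(SCc2nc3ccccc3[nH]2)nc1-c1ccccc1` gives 3.2 nM and compound 2 `N#Cc1c(Nc2nccs2)nc(SCc2nc3ccccc3[nH]2)nc1-c1ccccc1` gives 2.55 nM while compound 3 `N#Cc1c(NC(N)=O)nc(SCc2nc3ccccc3[nH]2)nc1-c1ccccc1` gives 3.37 nM (all three level within the scatter). Within the data shown here, the next compound, compound 4 `CN1CCN(c2nc(SCc3nc4ccccc4[nH]3)nc(-c3ccccc3)c2C#N)CC1`, carries 4-methylpiperazin-1-yl in place of ureido on an aromatic carbon (the only change from compound 3). The measured steps of a 1.3-fold lower number from compound 1 to compound 2 (0.10 log units; within the scatter) and a 1.1-fold higher number from compound 1 to compound 3 (0.02 log units; within the scatter) and a 1.3-fold higher number from compound 2 to compound 3 (0.12 log units; within the scatter) are all small and bear on this change. None of these compounds carries a six-membered non-aromatic ring at this place, so the expected range stays wide. In this assay the expected step is a 1.1-fold lower number from compound 3 to compound 4 (0.02 log units; within the scatter) and no shift beyond the scatter is expected. Compound 4 is estimated at 3.2 nM (expected range 1.5 nM to 7 nM).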

Compound 4, half-maximal inhibitory concentration: 6.9 nM
Estimate against measurement, compound 4: 2.2-fold (0.33 log units) below; the measured number falls inside the stated range.
By their numbers in this assay, from the lowest: compounds 2, 1 and 3 (each within the scatter of the next); then compound 4.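

In this assay, this aromatic carbon had carried hydroxy, (1,3-thiazol-2-yl)amino and ureido with no shift beyond the scatter, and 4-methylpiperazin-1-yl now gives the first separation (a 2.0-fold higher number from compound 3 to compound 4 (0.31 log units; beyond the scatter); a 2.7-fold higher number from compound 2 to compound 4 (0.43 log units; beyond the scatter); a 2.2-fold higher number from compound 1 to compound 4 (0.33 log units; beyond the scatter)). So the group at this position can move the number, though all three steps are modest. Nothing measured here accounts for the shift. The compounds shown leave open whether the shift goes with the six-membered non-aromatic ring or with its methyl group. Unsubstituted piperazin-1-yl or morpholin-4-yl at this position would help separate the two.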